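A few compounds are considered here, and "the series" means these few. Any claim that something is new, unique, unknown or untested is made for them only; others in the source may bear on it.

Series notes. In a functional assay on A2780 cells (Homo sapiens) for inhibition, read by sulforhodamine B assay (on this read-out higher numbers stand for weaker inhibition of growth and lower numbers for stronger inhibition of growth), compound 1 (`Fc1ccc(-c2ccc(-c3ccc(-c4nc5ccccc5[nH]4)cc3)cc2)cc1`) gives 48200 nM, compound 2 (`Oc1ccc(-c2ccc(-c3ccc(-c4nc5ccccc5[nH]4)cc3)cc2)cc1`) gives 36000 nM and compound 3 (`Oc1ccc(-c2ccc(-c3ccc(-c4nc5c(O)cccc5[nH]4)cc3)cc2)cc1`) gives 2920 nM. Compound 2 therefore sits within the scatter of compound 1 and well above compound 3 on the numbers.

The next comparison is compound 4 (`Cc1ccc2[nH]c(-c3ccc(-c4ccc(-c5ccc(O)cc5)cc4)cc3)nc2c1`), which carries methyl in place of hydrogen on an aromatic carbon. Among the compounds with values here, two measured steps bear on it. The change of a 1.3-fold lower number from compound 1 to compound 2 (0.13 log units; within the scatter) stays within the scatter, and it replaces fluoro rather than hydrogen, so it says little here. The large change of a 12-fold lower number from compound 2 to compound 3 (1.09 log units; beyond the scatter) is the only measured replacement of hydrogen by a group on an aromatic carbon, but that group is hydroxy. Within the data shown here, no methyl analogue has been measured, so only part of that gain is expected to carry over.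

In this assay, a small move toward lower numbers is expected, estimated as a 1.4-fold lower number from compound 2 to compound 4 (0.16 log units; within the scatter), and this may not clear the scatter. For compound 4 the estimated value is 25000 nM, with an expected range of 8000 nM to 60000 nM.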

Compound 4, concentration for 50% growth inhibition: 31200 nM
Compound 4: middle estimate off by 1.2-fold (0.10 log units), on the low side; low and high end bracket the measured number.
By their numbers in this assay, from the lowest: compound 3; then compounds 4, 2 and 1 (each within the scatter of the next).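

In this assay, methyl on an aromatic carbon of the six-membered aromatic ring of carbon only, part of a fused or bridged system of two rings, gives a 1.2-fold lower number from compound 2 to compound 4 (0.06 log units; within the scatter), so adding this one carbon on this position does not move the number beyond the scatter. The large gain seen with hydroxy, a 12-fold lower number from compound 2 to compound 3 (1.09 log units; beyond the scatter), therefore does not appear with methyl, although those two steps differ both in the group and in the carbon that carries it, so neither can be singled out as what matters. No measured evidence here accounts for the result.

Still open, going by these compounds, is whether a methoxy group or an amine on this same carbon would stay within the scatter of compound 2. On these data alone, it is also open whether methyl on the carbon bearing hydroxy in compound 3 would match that compound.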